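A few compounds are considered here, and "the series" means these few. Any claim that something is new, unique, unknown or untested is made for them only; others in the source may bear on it.

In an ADME assay on Vero cells (Chlorocebus sabaeus) for inhibition, read by sulforhodamine B assay, with a stated time of 48 h (a higher number here means a weaker inhibitor of growth, a lower number a stronger inhibitor of growth), compound 1 `CC1=CC[C@H](C(C)(C)NC(=S)N/N=C/c2ccccc2)CC1` gives 20500 nM. Compound 2 `COc1ccc(/C=N/NC(=S)NC(C)(C)[C@H]2CC=C(C)CC2)cc1` carries methoxy in place of hydrogen on an aromatic carbon relative to compound 1. In this assay compound 2 gives 12200 nM, so the step of a 1.7-fold lower number from compound 1 to compound 2 (0.23 log units; within the scatter) is a small one. Compound 3 `CC1=CC[C@H](C(C)(C)NC(=S)N/N=C(\C)c2ccccc2)CC1` is recorded in this assay only as a limit, > 100000 nM, which is the limit of > 100000 nM in this assay, at which 1 of the 3 values shown sits. How the core of compound 3 differs from the core of compound 1 is not broken down here. Compound 4 `COc1ccc(/C(C)=N/NC(=S)NC(C)(C)[C@H]2CC=C(C)CC2)cc1`, not yet measured, differs from compound 3 by methoxy in place of hydrogen on an aromatic carbon, the same change as from compound 1 to compound 2. The step of a number no higher from compound 3 to compound 4 (the limit leaves the size open) is expected to be of similar small size, because the earlier step was a 1.7-fold lower number from compound 1 to compound 2 (0.23 log units; within the scatter). Compound 4 is therefore estimated at 100000 nM, between 40000 nM and 300000 nM, and may well be reported in this assay only as a limit.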

Compound 4, concentration for 50% growth inhibition: > 100000 nM
Compound 4 ended at the assay's limit; the forecaster's own chance of this, stated with the estimate: 60%; the middle value sits exactly at the limit.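

No step can be read from compound 3 to compound 4 in this assay, as both values are limits: the limit of > 100000 nM in this assay, at which 2 of the 4 values shown sit.

The compounds shown leave open whether methoxy in place of hydrogen has any effect on the number when compound 3 is the starting point.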